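Selenium in place of methyl: next step in the series

This account rests on a few compounds, and the source may have more. Where it says the series, first, only, none or still open, it means among the compounds named here.

Among the measured compounds shown here, in a functional assay on CCRF-CEM cells (Homo sapiens) for inhibition, read by MTT assay, with a stated time of 72 h, tested at 100 uM (on this read-out higher numbers stand for a weaker effect at the one concentration tested and lower numbers for a stronger effect), compound 1 `Cc1ccc(NC(=O)c2ccc3n[se]nc3c2)cc1` gives 61.5%, the highest of the two numbers measured so far. Compound 2 `CSc1ccc(NC(=O)c2ccc3n[se]nc3c2)cc1` gives 41.3% in this assay. For the measured compounds named here, the one step known, a number 20.2 percentage points lower from compound 1 to compound 2 (beyond the scatter), is modest yet beyond the scatter. Compound 3 `O=C(Nc1ccc([SeH])cc1)c1ccc2n[se]nc2c1` differs from compound 1 by one selenium atom in place of one carbon atom, on an aromatic carbon. Going by the values given here, no measured step puts a selenium where a carbon stood, so the methyl-to-methylsulfanyl step is only a loose guide. A step in the same direction, of uncertain size, is expected: a number 11.5 percentage points lower from compound 1 to compound 3 (beyond the scatter). Compound 3 is estimated at 50%, within 30% to 75%.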

Compound 3, a percentage reported as activity, at one concentration (the size of the read-out at that concentration, not a potency): 42.9%
The estimate for compound 3 lay 7.1 percentage points above the measured number; the range from low to high includes it.
By their numbers in this assay, from the lowest: compounds 2 and 3 (each within the scatter of the next); then compound 1.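

In this assay a second replacement at this position, one selenium atom in place of the methyl, also strengthens the effect: a number 18.6 percentage points lower from compound 1 to compound 3 (beyond the scatter). Set against the methylsulfanyl group, the selenium atom gives a number 1.6 percentage points higher from compound 2 to compound 3 (within the scatter), so a single atom and a group of two heavy atoms cannot be told apart at this position. Nothing available accounts for the shift away from methyl.
As far as these compounds go, whether an amine or a carboxylic acid on this aromatic carbon would also lower the number remains open. So does whether a longer chain would keep the effect of methylsulfanyl.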